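Swapping a Naphthyl Cap for a Dimethylphenyl Cap

This account rests on a few compounds, and the source may have more. Where it says the series, first, only, none or still open, it means among the compounds named here.

Measured so far:
- compound 1 `O=C(CN(Cc1ccc(C(=O)NO)cc1)C(=O)c1cccc2ccccc12)NCc1ccccc1`: 0.69 h
- compound 2 `CC(C)c1ccc(C(=O)N(Cc2ccc(C(=O)NO)cc2)C(C)(C)C(=O)NC2CCCCC2)cc1`: 0.195 h
- compound 3 `CNC(=O)CN(Cc1ccc(C(=O)NO)cc1)C(=O)c1ccc(C(C)C)cc1`: 5.78 h

These three compounds were tested in an ADME assay on microsomes from liver (Homo sapiens) for metabolic stability, read by LC-MS, with a stated time of 40 min; on this read-out higher numbers stand for a longer-lived compound and lower numbers for a shorter-lived compound. Among them, compound 1 gives 0.69 h, which puts it second highest of the three numbers. Its nearest neighbour is compound 2, whose value of 0.195 h is lower by more than the usual scatter. The compound furthest from it is compound 3, whose value of 5.78 h is higher by a gap that is also beyond the scatter.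

The step followed here leads from compound 1 to compound 4 `Cc1ccc(C(=O)N(CC(=O)NCc2ccccc2)Cc2ccc(C(=O)NO)cc2)c(C)c1`, which has not yet been measured in this assay. The change is a single one: 2,4-dimethylphenyl in place of naphthalen-1-yl on a carbonyl carbon

Among the measured compounds shown here, no measured pair shows the effect of this exact change, so the expectation rests on compound 1 alone and on the spread seen across compounds 2 and 3. Without a shown step, the expected move a 1.2-fold higher number from compound 1 to compound 4 (0.06 log units; within the scatter) is modest and not clearly beyond the scatter in either direction. Compound 4 is therefore estimated at 0.8 h, with a likely range from 0.3 h to 2.2 h.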

Compound 4, half-life: 0.328 h
Beside the measured number, compound 4's estimate is 2.4-fold (0.39 log units) above it; the measured number falls inside the stated range.
By their numbers in this assay, from the lowest: compounds 2 and 4 (each within the scatter of the next); then compound 1; then compound 3.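

In this assay, putting 2,4-dimethylphenyl in place of naphthalen-1-yl on a carbonyl carbon gives a 2.1-fold lower number from compound 1 to compound 4 (0.32 log units; beyond the scatter), a modest step but one that can be read. Among the compounds shown here, this is the first direct view of this position. The earlier compounds shown here differ from one another in more than one place and could not isolate it. It shows that the group on this carbonyl carbon matters to the half-life on its own, and that one six-membered aromatic ring in place of two, with fewer heavy atoms, did not give a longer-lived compound in this single pair. Nothing measured here explains why the number fell.

Still open, as far as these compounds go, is whether each methyl group contributes on its own, and how a plain phenyl, a pyridine ring or a phenyl ring carrying a carboxylic acid or an amine would behave at this carbonyl carbon. One pair also cannot say whether the same swap would move the half-life the same way when the benzyl amide at the other end of the molecule is replaced by a different group.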